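The source may hold more compounds than are shown below. What is called first, only, known or untested is meant among the compounds shown, and "the series" means these compounds.

Measured so far, in an assay for inhibition of inositol hexakisphosphate kinase 3 (Homo sapiens), read by colorimetric assay, coupled enzyme assay and malachite green, with a stated time of 120 min, in the presence of a further agent that is not named here; on this read-out lower numbers stand for stronger inhibition and higher numbers for weaker inhibition:
- compound 1 `Cc1ccc(-c2onc3ccc(/C=C/C(=O)O)cc23)cc1`: compound 1 gives 11500 nM
- compound 2 `Cc1cccc(-c2onc3ccc(/C=C/C(=O)O)cc23)c1`: compound 2 gives 3590 nM

Going by the values given here, compound 2 stands at the lowest of the two numbers in this assay; its nearest neighbour is compound 1, and the only measured step, a 3.2-fold lower number from compound 1 to compound 2 (0.51 log units; beyond the scatter), separates them. That step concerns the methylphenyl substituent and says nothing about the acid-bearing side of the core.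

Compound 3 `Cc1cccc(-c2onc3ccc(C(=O)O)cc23)c1` is not yet measured. It differs from compound 2 in one place: carboxy in place of 2-carboxyethenyl on an aromatic carbon. Among the compounds with values here, no measured pair alters the 2-carboxyethenyl group, so no step bears directly on this change; the single step from compound 1 to compound 2 is the only scale of variation available and it is of modest size. Replacing the 2-carboxyethenyl group by carboxy shortens the acid-bearing chain on the core; the expectation for compound 3 is therefore a step toward a higher number in this assay, of roughly a 1.9-fold higher number from compound 2 to compound 3 (0.29 log units; within the scatter), with wide uncertainty in both directions. Compound 3 is expected to give about 7000 nM, within a range from 2000 nM to 30000 nM.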

Compound 3, half-maximal inhibitory concentration: 1410 nM
Estimate against measurement, compound 3: 5.0-fold (0.70 log units) above; the whole stated range lies above it.
By their numbers in this assay, from the lowest: compound 3; then compound 2; then compound 1.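

The acid-bearing position, which the earlier pair left untouched, proves responsive in this assay: with carboxy in place of 2-carboxyethenyl on an aromatic carbon, the series shows a 2.5-fold lower number from compound 2 to compound 3 (0.41 log units; beyond the scatter). The change removes two heavy atoms and one double bond outside aromatic rings, while the counts of one hydrogen-bond donor and one hydrogen-bond acceptor stay the same, so in the 3-methylphenyl setting the full 2-carboxyethenyl group is not needed to reach the lower number, and this position now gives a step of modest size alongside the one on the methylphenyl side, a 3.2-fold lower number from compound 1 to compound 2 (0.51 log units; beyond the scatter). Nothing available accounts for the direction of the step at the acid-bearing position.

Still open, as far as these compounds go, is whether the step seen on replacing 2-carboxyethenyl by carboxy carries over when 4-methylphenyl stands in place of 3-methylphenyl, since both changes have so far been seen only singly. Also open is how far the carboxylic acid itself matters at this place, as the compounds shown do not say how a primary amide, a hydroxymethyl group, a tetrazole or a saturated propanoic acid chain would compare with carboxy.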